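Acylthiourea series: removing the cyano group

The source may hold more compounds than are shown below. What is called first, only, known or untested is meant among the compounds shown, and "the series" means these compounds.

Within the data shown here, compound 3 `N#Cc1ccc2[nH]c(-c3cccc(NC(=S)NC(=O)c4ccc5c(c4)OCCO5)c3)nc2c1` gives 1000 nM in a functional assay on HUVEC cells (Homo sapiens) for cytotoxicity, read by WST assay, with a stated time of 48 h (a higher number here means a weaker inhibitor, a lower number a stronger inhibitor), the lowest of the two numbers measured so far. The nearest is compound 2 `CCOc1ccc(C(=O)NC(=S)Nc2cccc(-c3nc4ccccc4[nH]3)c2)cc1OCC`, whose value in this assay, 8000 nM, lies beyond the scatter from that of compound 3. For compound 1 `O=C(NC(=S)Nc1cccc(-c2nc3ccccc3[nH]2)c1)c1ccccc1` this assay reports > 10000 nM, which is a limit rather than a number. One of the three results is thus (the limit of > 10000 nM in this assay, at which 1 of the 3 values shown sits).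

Compound 4 `O=C(NC(=S)Nc1cccc(-c2nc3ccccc3[nH]2)c1)c1ccc2c(c1)OCCO2` is still to be measured in this assay. It differs from compound 3 in one place: hydrogen in place of cyano on an aromatic carbon. Among the measured compounds shown here, no measured pair shows this change directly. Compounds 1 and 2 both lack the cyano group and both sit at high numbers or at the limit, while compound 3 carries it and gives the lowest number; on two comparisons this is a thin pattern, but it points toward a weaker inhibitor after the change. The change is expected to give a step of a 4.0-fold higher number from compound 3 to compound 4 (0.60 log units; beyond the scatter) in this assay, toward a weaker inhibitor and beyond the scatter. For compound 4 the estimate in this assay is 4000 nM, with a range from 1500 nM to 10000 nM.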

Compound 4, half-maximal inhibitory concentration: 50 nM
Beside the measured number, compound 4's estimate is 80-fold (1.90 log units) above it, and the stated range ends above it.
By their numbers in this assay, from the lowest: compound 4; then compound 3; then compound 2. At a limit, above all of these: compound 1.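

Hydrogen in place of cyano on this aromatic carbon now has a direct reading: in this assay the change gives a 20-fold lower number from compound 3 to compound 4 (1.30 log units; beyond the scatter), so in this pair the compound with the cyano group is the weaker inhibitor, and a low number in this series does not require that group. With the 1H-benzimidazol-2-yl group held constant, the acyl side also matters: 2,3-dihydro-1,4-benzodioxin-6-yl in place of phenyl gives an at least 200-fold lower number from compound 1 to compound 4 (2.30 log units; beyond the scatter). The size of that step rests on compound 1, whose entry is a limit and not a number: the limit of > 10000 nM in this assay, at which 1 of the 4 values shown sits.

From the compounds shown here alone, it remains open whether any group on this aromatic carbon raises the number or only cyano does; a fluorine, a methoxy group or an amine there would separate these cases. Going by these compounds, each step is also a single pair, so it is unknown whether the cyano step carries over to other acyl groups.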